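Swapping the Carbamate Cap on a Solubility Series

A few compounds are considered here, and "the series" means these few. Any claim that something is new, unique, unknown or untested is made for them only; others in the source may bear on it.

Compound 2 `COc1cc2ncnc(-n3nc(-c4ccccn4)nc3N)c2cc1OCCNC(=O)OC(C)(C)C` is the less soluble of the two measured compounds in a physicochemical assay for solubility, in phosphate buffer, with a stated time of 18 h, at pH 7.4 (on this read-out lower numbers stand for lower solubility and higher numbers for higher solubility), where compound 2 gives 2000 nM. Among the measured compounds shown here, compound 1 `COCCOc1cc2c(-n3nc(-c4ccccn4)nc3N)ncnc2cc1OC` gives 8000 nM in this assay, and the single measured step, a 4.0-fold lower number from compound 1 to compound 2 (0.60 log units; beyond the scatter), is the only guide available. Compound 3 `COc1cc2ncnc(-n3nc(-c4ccccn4)nc3N)c2cc1OCCCNC(=O)OCC(F)(F)F` differs from compound 2 by (((2,2,2-trifluoroethoxy)carbonyl)amino)methyl in place of (tert-butoxycarbonyl)amino on a saturated chain carbon, two bonds along the chain from an oxygen on an aromatic ring. For the measured compounds named here, no measured step covers an exchange of one carbamate for another with a chain one carbon longer, so the step from compound 1 to compound 2 bears only loosely on it: compound 2 already carries a carbamate on this chain, and the move to compound 3 changes its cap and length rather than adding one. The expected step is therefore small, most likely none beyond the scatter, with a slight lean toward a lower number, and a 1.3-fold lower number from compound 2 to compound 3 (0.12 log units; within the scatter) is the estimated change. Compound 3 is expected to give 1500 nM, within a range from 500 nM to 5000 nM.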

Compound 3, solubility: 100 nM
The estimate for compound 3 lay 15-fold (1.18 log units) above the measured number, and the stated range ends above it.
By their numbers in this assay, from the lowest: compound 3; then compound 2; then compound 1.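

In this assay, the exchange of (tert-butoxycarbonyl)amino for (((2,2,2-trifluoroethoxy)carbonyl)amino)methyl gives a 20-fold lower number from compound 2 to compound 3 (1.30 log units; beyond the scatter). This is a larger step than a 4.0-fold lower number from compound 1 to compound 2 (0.60 log units; beyond the scatter), so at this place, altering a carbamate already on the chain can matter more than the earlier exchange of methoxy for a carbamate, and the whole span reaches an 80-fold lower number from compound 1 to compound 3 (1.90 log units; beyond the scatter). No measurement at hand bears on why the number fell so far.

The step joins a different carbamate cap to a longer chain, and the compounds shown cannot separate those two changes. From the compounds shown here alone, how an amine or a carboxylic acid at the end of this chain would read in this assay also stays open.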